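Cytotoxicity notes: amide aryl swap on the shared core

This account rests on a few compounds, and the source may have more. Where it says the series, first, only, none or still open, it means among the compounds named here.

Measured compounds:
- compound 1 `CC(C)n1ncc2c(C(=O)Nc3ccc(F)cc3F)cc(-c3cccs3)nc21`: > 200000 nM
- compound 2 `CC(C)n1ncc2c(C(=O)Nc3cccc(S(=O)(=O)N(C)C)c3)cc(-c3cccs3)nc21`: > 200000 nM
- compound 3 `CC(C)n1ncc2c(C(=O)Nc3ccccc3F)cc(-c3ccncc3)nc21`: 45000 nM

In an ADME assay on LLC-MK2 cells (Macaca mulatta) for cytotoxicity, read by spectrophotometry and crystal violet staining, with a stated time of 4 days (on this read-out higher numbers stand for lower toxicity in this test and lower numbers for higher toxicity in this test), compound 1 gives > 200000 nM, which is a limit of the assay and not a number. Compound 2 likewise gives a limit, > 200000 nM. Among the compounds with values here, compound 3 is the only compound with a numeric value, 45000 nM. Within the data shown here, compound 1 therefore stands at the limit of > 200000 nM in this assay, at which 2 of the 3 values shown sit, and no step between measured compounds that differ in one place is available, so no measured size of step can be drawn on.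

Compound 4 `CC(C)n1ncc2c(C(=O)Nc3ccncn3)cc(-c3cccs3)nc21` differs from compound 1 by pyrimidin-4-yl in place of 2,4-difluorophenyl on an amide-type nitrogen. With only limits for the closest measured compounds, the expectation for the step of an at least 1.3-fold lower number from compound 1 to compound 4 (0.12 log units; that floor lies within the scatter) is a small one, in the direction of higher toxicity if anything, and probably not beyond the scatter. For compound 4 the estimated value in this assay is 150000 nM, with a range of 40000 nM to 300000 nM; a limit rather than a number is a real possibility.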

Compound 4, half-maximal cytotoxic concentration: 50000 nM
The estimate for compound 4 lay 3.0-fold (0.48 log units) above the measured number; low and high end bracket the measured number.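

In this assay, pyrimidin-4-yl in place of 2,4-difluorophenyl on the amide-type nitrogen gives an at least 4.0-fold lower number from compound 1 to compound 4 (0.60 log units; beyond the scatter). Within the data shown here, this is the first measured step, and it shows that a change at this position alone, with the rest of compound 1 kept, is enough to give a numeric value in this read-out. The value of compound 1, > 200000 nM, is a limit of the assay and not a number, so the step is a floor and its full size stays unknown: the limit of > 200000 nM in this assay, at which 2 of the 4 values shown sit.

The compounds shown do not separate the part played by the entering ring nitrogens from that of the leaving fluorines; an unsubstituted phenyl or a pyridin-3-yl group on the same nitrogen would bear on this. From the compounds shown here alone, whether the step carries over to the other compounds also remains open.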